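The compounds below may be only part of what the source reports. "The series", "measured", "known", "first", "only" and "open" are said of these compounds alone.

Among the compounds with values here, compound 2 `CS(=O)(=O)c1ccc(-c2cnc3[nH]cc(-c4nnc(-c5ccc(F)cc5)o4)c(=O)c3c2)cc1` is one of two compounds measured in a functional assay on A549 cells (Homo sapiens) for inhibition, read by MTT assay, with a stated time of 24 h, tested at 10 uM; a lower number here means less inhibition of growth, a higher number more inhibition of growth at the concentration tested. In this assay compound 2 gives 3.59%, and compound 1 `CS(=O)(=O)c1ccc(-c2cnc3[nH]cc(-c4nnc(-c5ccncc5)o4)c(=O)c3c2)cc1` gives 12.1%. Within the data shown here, the single step between them, a number 8.5 percentage points lower from compound 1 to compound 2 (within the scatter), lies within the scatter, so the two compounds are not told apart. Compound 3 `CS(=O)(=O)c1ccc(-c2cnc3[nH]cc(-c4nnc(-c5ccccc5)o4)c(=O)c3c2)cc1` differs from compound 2 by hydrogen in place of fluoro on an aromatic carbon, on an aromatic carbon of a six-membered aromatic ring of carbon only. Among the measured compounds shown here, only that one small step bears on this change, so no step beyond the scatter is expected; the expected step is a number 2.4 percentage points higher from compound 2 to compound 3 (within the scatter). Compound 3 is therefore estimated at 6%, with a range from -5% to 17%.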

Compound 3, percent growth inhibition at one concentration: 9.51%
The estimate for compound 3 lay 3.5 percentage points below the measured number; measured number inside the range.
By their numbers in this assay, from the lowest: compounds 2, 3 and 1 (each within the scatter of the next).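

Removing the fluoro gives a number 5.9 percentage points higher from compound 2 to compound 3 (within the scatter), so in this assay fluoro and hydrogen at this place on the phenyl ring are not told apart. The step of a number 2.6 percentage points lower from compound 1 to compound 3 (within the scatter) likewise does not separate phenyl from pyridin-4-yl, so compounds 1, 2 and 3 all lie within the scatter of one another. Nothing at hand bears on a cause for these small steps. Still open, going by these compounds, is whether an amine, a carboxylic acid or a longer chain at this place would give a step beyond the scatter.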